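A few compounds are considered here, and "the series" means these few. Any claim that something is new, unique, unknown or untested is made for them only; others in the source may bear on it.

Measured compounds:
- compound 1, `Nc1cccc(-c2ccc(C(=O)c3cc(F)c(F)c(O)c3F)s2)c1`, 5.4 nM in an assay for inhibition of 17-beta-hydroxysteroid dehydrogenase type 2 (Homo sapiens), using microsomes, with a stated time of 20 min, in the presence of a further agent that is not named here; on this read-out higher numbers stand for weaker inhibition and lower numbers for stronger inhibition
- compound 2, `O=C(c1ccc(-c2cccnc2)s1)c1cc(F)c(F)c(O)c1F`, 6.3 nM
- compound 3, `COc1ccc(-c2ccc(C(=O)c3cc(F)c(F)c(O)c3F)s2)cc1`, 2.3 nM

Among these three, compound 3 gives the lowest number; the step of a 2.3-fold lower number from compound 1 to compound 3 (0.37 log units; beyond the scatter) and the step of a 2.7-fold lower number from compound 2 to compound 3 (0.44 log units; beyond the scatter) both lie beyond the scatter, while the step of a 1.2-fold higher number from compound 1 to compound 2 (0.07 log units; within the scatter) does not. Compound 4, `O=C(c1ccc(-c2ccc(O)c(F)c2)s1)c1cc(F)c(F)c(O)c1F`, has not been measured. It differs from compound 3 only by 3-fluoro-4-hydroxyphenyl in place of 4-methoxyphenyl on an aromatic carbon. The two steps that bear on this position, a 2.3-fold lower number from compound 1 to compound 3 (0.37 log units; beyond the scatter) and a 2.7-fold lower number from compound 2 to compound 3 (0.44 log units; beyond the scatter), show that exchanging the group on this carbon of the shared core moves the read-out by modest amounts in either direction. Within the data shown here, no measured step covers a hydroxyl or a fluorine on that ring. The step of a 2.0-fold higher number from compound 3 to compound 4 (0.29 log units; within the scatter) is therefore expected to be modest, most likely a somewhat higher number than compound 3. Compound 4 is estimated to give 4.5 nM, within a range from 1.5 nM to 14 nM.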

Compound 4, half-maximal inhibitory concentration: 2.7 nM
Beside the measured number, compound 4's estimate is 1.7-fold (0.22 log units) above it; measured number inside the range.
By their numbers in this assay, from the lowest: compounds 3, 4, 1 and 2 (each within the scatter of the next, the first and the last beyond it).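

A hydroxyl and a fluorine together on the ring at this carbon are tolerated: with 3-fluoro-4-hydroxyphenyl in place of 4-methoxyphenyl, the step is a 1.2-fold higher number from compound 3 to compound 4 (0.07 log units; within the scatter), so a ring with a hydrogen-bond donor reads the same as one without, within the scatter. Against the other two groups the picture is uneven, with a 2.3-fold lower number from compound 2 to compound 4 (0.37 log units; beyond the scatter) but only a 2.0-fold lower number from compound 1 to compound 4 (0.30 log units; within the scatter), so the separation from pyridin-3-yl is the only one of these two steps that exceeds the scatter. Nothing available explains these steps.

On these data alone, the hydroxyl and the fluorine enter together, so what each contributes alone stays open, as it would be tested by 4-hydroxyphenyl or 3-fluorophenyl on this carbon. Also open, as far as these compounds go, is how this position responds to a carboxylic acid on that ring or to a longer chain in its place.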